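The source may report more compounds than this note shows. Statements on the series, on what has been measured and on what is new or still open speak of the compounds shown alone.

Measured compounds:
Compound 1, `Fc1cccc(Cc2nnc(Cn3nnc4ccccc43)o2)c1`, gives 237000 nM in a functional assay on HeLa cells (Homo sapiens) for antiproliferative activity, read by MTT assay, with a stated time of 24 h; a lower number here means a stronger inhibitor, a higher number a weaker inhibitor.
Compound 2, `COc1cccc(Cc2nnc(Cn3nnc4ccccc43)o2)c1`, gives 123000 nM in this assay.
Compound 3, `Fc1cccc(-c2nnc(Cn3nnc4ccccc43)o2)c1`, gives 332000 nM in this assay.

Compound 1 and compound 2 share one core and differ in a single spot: methoxy in place of fluoro on an aromatic carbon. That change produced a 1.9-fold lower number from compound 1 to compound 2 (0.28 log units; within the scatter). Compound 3 carries another core; how the core of compound 3 differs from the core of compound 1 is not broken down here. Compound 4, `COc1cccc(-c2nnc(Cn3nnc4ccccc43)o2)c1`, has not yet been measured in this assay. It stands to compound 3 exactly as compound 2 stands to compound 1: methoxy in place of fluoro on an aromatic carbon. The place of the change reads the same in both pairs, so this is the same change repeated on a second core. Going by the values given here, only one earlier example of it exists, and that step stayed within the scatter, so any expectation for compound 4 rests on a single, small step. On that basis the expected step is a 1.8-fold lower number from compound 3 to compound 4 (0.27 log units; within the scatter), close in size to a 1.9-fold lower number from compound 1 to compound 2 (0.28 log units; within the scatter). Compound 4 is therefore estimated at 180000 nM in this assay.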

Compound 4, half-maximal inhibitory concentration: 243000 nM
Beside the measured number, compound 4's estimate is 1.4-fold (0.13 log units) below it, within the range that was stated.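

Replacing fluoro with methoxy on the second core gave a 1.4-fold lower number from compound 3 to compound 4 (0.14 log units; within the scatter) in this assay. Set beside the first example, the two steps agree: the same change on two cores in this assay, a 1.9-fold lower number (0.28 log units; within the scatter) from compound 1 to compound 2 and a 1.4-fold lower number (0.14 log units; within the scatter) from compound 3 to compound 4, 1.4-fold (0.15 log units) apart, within the scatter of two such steps. This shows that the change behaved alike on the two cores, with a small step each time, but both steps lie within the scatter, so neither shows that methoxy and fluoro truly differ here, and two cores cannot predict what a third would do.

The compounds shown carry only fluoro or methoxy at this place, so it remains open whether an amine, a carboxylic acid or a longer chain such as butoxy would shift the number beyond the scatter on either core. As far as these compounds go, all four numbers come from this assay, so it also remains open whether the two cores would respond alike to this change in a different test.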